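The source may hold more compounds than are shown below. What is called first, only, known or untested is meant among the compounds shown, and "the series" means these compounds.

Compound 1, `CCCCCCCCCCCCCc1nc2ccccc2[nH]1`, gives 22900 nM in an ADME assay on microsomes from liver for inhibition of cytochrome P450 2B1 (Rattus norvegicus); on this read-out lower numbers stand for stronger inhibition and higher numbers for weaker inhibition.
Compound 2, `CCCCC(=O)Nc1ccc2[nH]c(C)nc2c1`, gives 417000 nM in this assay.
Compound 3, `Brc1ccccc1OCc1nc2ccccc2[nH]1`, gives 12000 nM in this assay.

Among these three, compound 3 has the lowest number. Its gap to compound 1 falls within the usual scatter, so no order between the two can be read; compound 2 sits well beyond the scatter with a far higher number. Compound 4, `Brc1ccc(OCc2nc3ccccc3[nH]2)c(Br)c1`, differs from compound 3 by bromo in place of hydrogen on an aromatic carbon, the new bromo sitting meta to a bromo group and para to a large group. Among the measured compounds shown here, no two measured compounds differ in a single place, so no measured step guides this change. The expected step is small, toward a lower number in this assay, a 1.5-fold lower number from compound 3 to compound 4 (0.18 log units; within the scatter), and not clearly beyond the scatter. Compound 4 is therefore estimated at 8000 nM, with a likely range from 3000 nM to 25000 nM.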

Compound 4, half-maximal inhibitory concentration in the cytochrome P450 2B1 assay: 11000 nM
Compound 4: the middle estimate sits 1.4-fold (0.14 log units) below what was measured; low and high end bracket the measured number.
By their numbers in the cytochrome P450 2B1 assay, from the lowest: compounds 4, 3 and 1 (each within the scatter of the next, the first and the last beyond it); then compound 2.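

In the cytochrome P450 2B1 assay, bromo in place of hydrogen on this aromatic carbon gives the only single-place step among these compounds, a 1.1-fold lower number from compound 3 to compound 4 (0.04 log units; within the scatter), so no effect on inhibition can be read at this position. In a physicochemical assay for lipophilicity (on this read-out lower numbers stand for lower lipophilicity and higher numbers for higher lipophilicity), compound 3 gives 3.51 and compound 4 gives 4.52, so the same change moves the number clearly, and a large shift in partition coefficient comes with no readable shift in inhibition: the measured partition coefficient of compound 3, 3.51, and of compound 4, 4.52, a number 1.01 log units higher (beyond the scatter).

Still open, on these data alone, is whether an amine or a methoxy group on this same carbon would move the number in the cytochrome P450 2B1 assay. One step at one position also cannot show how bromo behaves elsewhere on the ring.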